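The source may report more compounds than this note shows. Statements on the series, on what has been measured and on what is new or still open speak of the compounds shown alone.

Measured so far in a toxicity assay on WI-38 cells (Homo sapiens) for cytotoxicity, read by MTT assay, with a stated time of 48 h; a higher number here means a weaker inhibitor, a lower number a stronger inhibitor:
compound 1, `O=C(/C=C/c1ccc2c(c1)B(O)OC2)c1ccco1`: 59000 nM
compound 2, `Cc1ccc(C(=O)/C=C/c2ccc3c(c2)B(O)OC3)cc1`: 22200 nM

Compound 2 holds the lowest of the two numbers; its nearest neighbour is compound 1, which stands a step of a 2.7-fold lower number from compound 1 to compound 2 (0.42 log units; beyond the scatter) away, the change being 4-methylphenyl in place of furan-2-yl on a carbonyl carbon. Compound 3, `O=C(O)c1ccc(C(=O)/C=C/c2ccc3c(c2)B(O)OC3)cc1`, is not yet measured. It differs from compound 2 in one place: carboxy in place of methyl on an aromatic carbon. Among the compounds with values here, the single measured step, a 2.7-fold lower number from compound 1 to compound 2 (0.42 log units; beyond the scatter), concerns the group on the carbonyl carbon and not the substituent on the six-membered aromatic ring, so it gives no direct guide to the present change; no step involving a carboxy group has been measured. For compound 3 the expected step is a 1.6-fold higher number from compound 2 to compound 3 (0.20 log units; within the scatter), a small rise that may well fall within the scatter. Compound 3 is therefore estimated at 35000 nM, with a range from 12000 nM to 90000 nM.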

Compound 3, half-maximal inhibitory concentration: > 100000 nM
Compound 3 was reported as a limit; the forecaster's own chance of this, stated with the estimate: 20%; middle value at least 2.8-fold (0.45 log units) from the limit.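

In this assay, the substituent on the six-membered aromatic ring now has a readable effect: carboxy in place of methyl on an aromatic carbon para to a large group gives an at least 4.5-fold higher number from compound 2 to compound 3 (0.65 log units; beyond the scatter), whereas the earlier step changed only the group on the carbonyl carbon. Taken with a 2.7-fold lower number from compound 1 to compound 2 (0.42 log units; beyond the scatter), this shows the number moving in both directions across the three compounds. Compound 3 is reported as a limit and not a number, so its step fixes only a lower bound on the size of the change: the limit of > 100000 nM in this assay, at which 1 of the 3 values shown sits.

Open, as far as these compounds go, is whether the rise belongs to the carboxylic acid as such or would also come with a methyl ester or a primary amide at this position. Also open, from the compounds shown here alone, is how an amine or a methoxy group there would compare with compound 2 at 22200 nM.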